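Replacing 4-chlorophenyl with pyridin-3-yl in compound 1

A few compounds are considered here, and "the series" means these few. Any claim that something is new, unique, unknown or untested is made for them only; others in the source may bear on it.

Measured in an ADME assay on Vero cells (Chlorocebus sabaeus) for cytotoxicity, read by MTT assay, with a stated time of 72 h; on this read-out lower numbers stand for higher toxicity in this test and higher numbers for lower toxicity in this test:
compound 1 `CC1(C)C=Cc2c(ccc(C(=O)/C=C/c3ccc(Cl)cc3)c2O)O1`: 92200 nM
compound 2 `CC1(C)C=Cc2c(ccc(C(=O)/C=C/c3ccc([N+](=O)[O-])cc3)c2O)O1`: 106000 nM

Only these two numbers are available in this assay, and compound 1 has no separate standing from compound 2: the step between them is a 1.1-fold higher number from compound 1 to compound 2 (0.06 log units; within the scatter).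

The change in question leads from compound 1 to compound 3 `CC1(C)C=Cc2c(ccc(C(=O)/C=C/c3cccnc3)c2O)O1`: pyridin-3-yl in place of 4-chlorophenyl on a double-bonded chain carbon bound to a double-bonded chain carbon. The new group sits on a double-bonded chain carbon bound to a double-bonded chain carbon, and the rest of the core of compound 1 stays the same.

Within the data shown here, one measured step bears on this, since the exchange of nitro for chloro alters the same 4-chlorophenyl group that leaves here. Among the measured compounds shown here, it is thin evidence, as no measured compound carries an aromatic ring with a hetero atom. For the measured compounds named here, with a 1.1-fold higher number from compound 1 to compound 2 (0.06 log units; within the scatter) as the only guide, no shift beyond the scatter is expected in either direction. The expected step is a 1.1-fold higher number from compound 1 to compound 3 (0.06 log units; within the scatter). For compound 3 the estimated value is 105000 nM, with an expected range from 52000 nM to 210000 nM.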

Compound 3, half-maximal cytotoxic concentration: 8600 nM
Beside the measured number, compound 3's estimate is 12-fold (1.09 log units) above it, outside the stated range (below it).
By their numbers in this assay, from the lowest: compound 3; then compounds 1 and 2 (each within the scatter of the next).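

In this assay, pyridin-3-yl in place of 4-chlorophenyl on a double-bonded chain carbon bound to a double-bonded chain carbon gives an 11-fold lower number from compound 1 to compound 3 (1.03 log units; beyond the scatter), so this place is not indifferent to the group it carries, something the earlier pair could not show, as nitro in place of chloro gave only a 1.1-fold higher number from compound 1 to compound 2 (0.06 log units; within the scatter). Compounds 1 and 2, which both keep a six-membered aromatic ring of carbon only, stand within the scatter of each other, while compound 3, the only one of the three whose ring holds a hetero atom, moves beyond the scatter from compound 1. Nothing available here accounts for the size of this step.

The exchange puts a nitrogen into the ring and removes the chlorine in one move, so the compounds shown leave open which of the two goes with the lower number. As far as these compounds go, a plain phenyl group or a chlorine-bearing pyridine ring at this place would separate the two, and it also remains open whether the step holds for a pyridine ring joined through another of its carbons.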